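From 2,6-dichlorophenyl to 2,4-dichlorophenyl in compound 3

The source may hold more compounds than are shown below. What is called first, only, known or untested is meant among the compounds shown, and "the series" means these compounds.

Two compounds have values so far in a functional assay on L1210 cells (Mus musculus) for cytotoxicity, read by MTT assay, with a stated time of 24 h (on this read-out lower numbers stand for stronger inhibition and higher numbers for weaker inhibition), as follows
compound 1 `COc1cc(C(=O)/C=C/c2c(Cl)cccc2Cl)cc(OC)c1OC` gives 50500 nM
compound 2 `COc1cc(C(=O)/C=C/c2ccc(Cl)c(C(F)(F)F)c2)cc(OC)c1OC` gives 47500 nM

Going by the values given here, compound 1 stands level with compound 2, the only other compound measured, since their two values lie within the usual scatter of each other. Compound 3 `COc1cc(C(=O)/C=C/c2ccc(Cl)cc2Cl)cc(OC)c1OC` has not yet been measured. It carries 2,4-dichlorophenyl in place of 2,6-dichlorophenyl on a double-bonded chain carbon bound to a double-bonded chain carbon and otherwise keeps the core of compound 1. Among the compounds with values here, no measured pair differing in one place is available, so the data do not show how large such a change can be in this assay on their own. Within the data shown here, the only guide is the close agreement of compound 1 at 50500 nM and compound 2 at 47500 nM in the same range. On that basis, no step beyond the scatter is expected, only a slight drift toward a lower number, and the estimate is a 1.3-fold lower number from compound 1 to compound 3 (0.12 log units; within the scatter) within the scatter. The estimated value for compound 3 is 38000 nM (expected range 14000 nM to 80000 nM).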

Compound 3, half-maximal inhibitory concentration: 52500 nM
Compound 3: the middle estimate sits 1.4-fold (0.14 log units) below what was measured, within the range that was stated.
By their numbers in this assay, from the lowest: compounds 2, 1 and 3 (each within the scatter of the next).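

Going by these compounds alone, exchanging 2,6-dichlorophenyl for 2,4-dichlorophenyl on a double-bonded chain carbon bound to a double-bonded chain carbon gives the first comparison at a single place in this assay, and the result is a 1.0-fold higher number from compound 1 to compound 3 (0.02 log units; within the scatter). Where the earlier compounds offered no pair differing in one place, this pair shows that, with the core of compound 1 kept, this particular exchange between two dichlorophenyl groups leaves the read-out unchanged within the usual scatter, so this change gives no sign that the read-out at this place depends on which of these two dichlorophenyl groups is present. Nothing available explains this outcome.

Going by these compounds, the pair cannot say how the read-out at this place responds to a larger change, since both groups have the same atoms and the same counts, and whether an unsubstituted phenyl, or a phenyl carrying an amine or a carboxylic acid, would give a step beyond the scatter stays open. On these data alone, whether the shared core itself can be altered while the read-out in this assay moves to markedly lower numbers also stays open.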